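A few compounds are considered here, and "the series" means these few. Any claim that something is new, unique, unknown or untested is made for them only; others in the source may bear on it.

Going by the values given here, in a functional assay on HCT-15 cells (Homo sapiens) for cytotoxicity (a higher number here means a weaker inhibitor, a lower number a stronger inhibitor), compound 2 `Cc1nn(C)c(Oc2ccc(Cl)cc2)c1/C=N/OCc1ccc(C(=O)OC(C)(C)C)cc1` gives 0.01 ug/mL, the lowest of the two numbers measured so far, while compound 1 `Cc1nn(C)c(-n2cccc2)c1/C=N/OCc1ccc(C(=O)OC(C)(C)C)cc1` gives 2.48 ug/mL. Compound 3 `Cc1nn(C)c(N2CCCC2)c1/C=N/OCc1ccc(C(=O)OC(C)(C)C)cc1` carries pyrrolidin-1-yl in place of 4-chlorophenoxy on an aromatic carbon. Among the compounds with values here, the one measured step that bears on this change is a 250-fold lower number from compound 1 to compound 2 (2.39 log units; beyond the scatter), where a five-membered ring joined through nitrogen gave way to the 4-chlorophenoxy group. Compound 3 returns to a five-membered ring joined through nitrogen, now a saturated one, so a large rise in the number is expected, a 150-fold higher number from compound 2 to compound 3 (2.18 log units; beyond the scatter). Compound 3 is thus estimated at 1.5 ug/mL, with a range from 0.2 ug/mL to 8 ug/mL.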

Compound 3, half-maximal inhibitory concentration: 0.1 ug/mL
The estimate for compound 3 lay 15-fold (1.18 log units) above the measured number; the whole stated range lies above it.
By their numbers in this assay, from the lowest: compound 2; then compound 3; then compound 1.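

Among the two five-membered rings on this aromatic carbon, pyrrolidin-1-yl in place of 1H-pyrrol-1-yl gives a 25-fold lower number from compound 1 to compound 3 (1.39 log units; beyond the scatter), so joining such a ring through nitrogen does not by itself set the number in this assay. The 4-chlorophenoxy group still holds the lowest number, with a 10-fold higher number from compound 2 to compound 3 (1.00 log units; beyond the scatter), a smaller step than the one that separates the pyrrol-1-yl compound from the 4-chlorophenoxy compound. No available measurement explains these differences. From the compounds shown here alone, it remains open whether an open-chain amine such as dimethylamino, or a phenoxy group without its chlorine, would stand nearer to compound 2 or to compound 3.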